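Exchanging a Benzyl Ring Substituent Under a Cytotoxicity Ceiling

This account rests on a few compounds, and the source may have more. Where it says the series, first, only, none or still open, it means among the compounds named here.

Compound 1 `CCOC(=O)c1cnc(N2CCN(Cc3ccccc3C#N)CC2)nc1Oc1c(C)cc(-c2ccc(C#N)cc2)cc1C` was tested in an ADME assay on MT4 cells (Homo sapiens) for cytotoxicity, read by MTT assay, with a stated time of 4 days; on this read-out lower numbers stand for higher toxicity in this test and higher numbers for lower toxicity in this test. In this assay compound 1 gives > 125000 nM, which is a limit of the assay rather than a number. Compound 2 `CCOC(=O)c1cnc(N2CCN(Cc3cccc(C(F)(F)F)c3)CC2)nc1Oc1c(C)cc(-c2ccc(C#N)cc2)cc1C` carries a trifluoromethyl group in place of the cyano group on the benzyl ring. In this assay compound 2 gives > 125000 nM, again a limit. Compound 3 `CCOC(=O)c1cnc(N2CCN(Cc3cccc(F)c3)CC2)nc1Oc1c(C)cc(-c2ccc(C#N)cc2)cc1C` carries a fluoro group at the corresponding place. In this assay compound 3 gives > 125000 nM, also a limit. The steps between these three are therefore a step that the two limits leave unreadable from compound 1 to compound 2, a step that the two limits leave unreadable from compound 1 to compound 3 and a step that the two limits leave unreadable from compound 2 to compound 3, as the limit of > 125000 nM in this assay, at which 3 of the 3 values shown sit, shows.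

Compound 4 `CCOC(=O)c1cnc(N2CCN(Cc3ccccc3F)CC2)nc1Oc1c(C)cc(-c2ccc(C#N)cc2)cc1C` has not yet been measured. Relative to compound 1 the change is fluoro in place of cyano on an aromatic carbon. For the measured compounds named here, none of the measured steps gives a readable size, so the only guidance is that every measured neighbour sits at the limit. Compound 4 is expected to behave the same way, with an estimated step that the limit leaves unreadable from compound 1 to compound 4. The value of compound 4 in this assay is therefore estimated at 150000 nM, with a likely range from 70000 nM to 400000 nM.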

Compound 4, half-maximal cytotoxic concentration: > 125000 nM
Compound 4: no number, only a limit; the forecaster's own chance of this, stated with the estimate: 85%; the middle value is on the limit's open side.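

In this assay compound 4 gives > 125000 nM, which is a limit and not a number. No step between compound 4 and compound 1, compound 2 or compound 3 can be read, because all four compounds share the same limit: the limit of > 125000 nM in this assay, at which 4 of the 4 values shown sit.

The compounds shown leave open whether any change on the benzyl ring would give a readable value.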